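From benzoyl to pyridin-3-yl on the amine nitrogen

This account rests on a few compounds, and the source may have more. Where it says the series, first, only, none or still open, it means among the compounds named here.

Compound 1 (`C[C@@H](Cn1ccc(-c2ccc(C#N)c(Cl)c2)n1)NC(=O)c1ccccc1`) has no number to anchor the step: in an ADME assay on L02 cells (Homo sapiens) for cytotoxicity, read by CCK-8 assay, with a stated time of 6 days (on this read-out lower numbers stand for stronger inhibition and higher numbers for weaker inhibition), compound 1 gives "not determined" (no result reported) as its entry. Compound 3 (`CC(Cn1ccc(-c2ccc(C#N)c(Cl)c2)n1)C(=O)Nc1cccc(C(C)O)c1`) is no help, since compound 3 also gives "not determined" (no result reported) as its entry. Compound 2 (`C[C@@H](Cn1ccc(-c2ccc(C#N)c(Cl)c2)n1)NC(=O)c1cccc(OCC(O)CO)c1`) reads > 30000 nM in this assay and this is a limit, not a number. Going by the values given here, the only reading in the set is thus the limit of > 30000 nM in this assay, at which 1 of the 3 values shown sits, and it belongs to compound 2.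

Compound 4 (`C[C@@H](Cn1ccc(-c2ccc(C#N)c(Cl)c2)n1)Nc1cccnc1`) carries pyridin-3-yl in place of benzoyl on an amine nitrogen. Among the compounds with values here, no measured step covers this change in this assay and compound 1 offers no value to step from. The expectation is therefore a reading in the same weak region as the limit of compound 2, with no step beyond the scatter and no clear direction. For compound 4 the estimated half-maximal inhibitory concentration is 30000 nM with an expected range from 12000 nM to 60000 nM in this series.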

Compound 4, half-maximal inhibitory concentration: > 30000 nM
Compound 4 ended at the assay's limit (the forecaster's own chance of this, stated with the estimate: 65%); the middle value lies on the limit itself.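

Compound 4 gives > 30000 nM in this assay, a limit and not a number. Going by these compounds alone, compound 1 gives "not determined" (no result reported), and no step from it to compound 4 can be read. The compounds shown leave open whether any change on the amine nitrogen moves this read-out off the limit.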